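Swapping Phenyl for Methyl on a Chk2 Core

This account rests on a few compounds, and the source may have more. Where it says the series, first, only, none or still open, it means among the compounds named here.

Among the measured compounds shown here, in an assay on isolated protein for inhibition of serine/threonine-protein kinase Chk2 (Homo sapiens), read by mobility shift assay, tested at 30 uM (a higher number here means more inhibition at the concentration tested (going by the name of the read-out), a lower number less inhibition), compound 2 `Cc1cc2nc(-c3ccccc3)nc(N)c2c(=O)[nH]1` gives 4%, the lowest of the two numbers known so far; compound 1 `Cc1cc2nc(N)nc(N)c2c(=O)[nH]1` gives 16%. For the measured compounds named here, the only measured step, a number 12 percentage points lower from compound 1 to compound 2 (beyond the scatter), came with phenyl in place of amino on an aromatic carbon and lowered inhibition beyond the scatter. Compound 3 `Cc1nc(N)c2c(=O)[nH]c(C)cc2n1` differs from compound 2 by methyl in place of phenyl on an aromatic carbon. Methyl is neither the amino of compound 1 nor the phenyl of compound 2, so only a slight rise, if any, is expected, and the step of a number 6 percentage points higher from compound 2 to compound 3 (within the scatter) is expected to stay within the scatter. The estimate for compound 3 is therefore 10%, with a range from 0% to 25%.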

Compound 3, a percentage reported as inhibition, at one concentration (the size of the read-out at that concentration, not a potency): 5%
For compound 3 the middle estimate is 5 percentage points above the measured one, and the stated range covers the measured number.
By their numbers in this assay, from the lowest: compounds 2 and 3 (each within the scatter of the next); then compound 1.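

Swapping the six-carbon phenyl for the one-carbon methyl at this position, between two ring nitrogen atoms, makes no readable difference: the result is a number 1 percentage points higher from compound 2 to compound 3 (within the scatter). Replacing amino with methyl gives a number 11 percentage points lower from compound 1 to compound 3 (beyond the scatter), much like the earlier change from amino to phenyl, so among these three compounds only compound 1, with its amino group, stands apart. No available evidence explains this pattern. As far as these compounds go, it remains open whether methylamino, dimethylamino or hydroxyl at this position would keep or raise the inhibition seen with compound 1.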